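One Methyl Group in a Series Without a Measured Potency

The source may report more compounds than this note shows. Statements on the series, on what has been measured and on what is new or still open speak of the compounds shown alone.

Of the compounds shown here, three sharing one core have so far been tested in a functional assay on HepG2 cells (Homo sapiens) for cytotoxicity, read by MTT assay, with a stated time of 24 h; a lower number here means a stronger inhibitor, a higher number a weaker inhibitor. Compound 1 (`COc1cc(O)cc(/C=C/c2ccc(OC)c(O)c2OC)c1`) gives > 100000 nM, which is a limit of the assay and not a number. Compound 2 (`COc1cc(O)cc(/C=C/c2cccc(OC)c2OC)c1`) gives > 100000 nM, again a limit. Compound 3 (`COc1cc(O)cc(/C=C/c2cccc(O)c2O)c1`) gives > 100000 nM, likewise a limit. Among the compounds with values here, compound 3 therefore stands with the other two at the limit of > 100000 nM in this assay, at which 3 of the 3 values shown sit, and the results offer no measured step between compounds to serve as a guide.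

Compound 4 (`COc1cc(O)cc(/C=C/c2cccc(O)c2OC)c1`) differs from compound 3 in one place. It has methyl in place of hydrogen on an oxygen on an aromatic ring, a difference counted as methyl in place of hydrogen on an oxygen on an aromatic ring and read as hydroxy to methoxy.

All three tested compounds sit at the same limit, so no direction is favoured in this assay, and no change beyond the scatter is expected. The expected size of the change is a number no higher from compound 3 to compound 4 (the limit leaves the size open) and nothing larger. Compound 4 is estimated at 100000 nM within an expected range from 50000 nM to 200000 nM, and a limit is expected again.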

Compound 4, half-maximal inhibitory concentration: 90800 nM
Estimate against measurement, compound 4: 1.1-fold (0.04 log units) above, within the range that was stated.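

In this assay, within the data shown here, compound 4 gives 90800 nM, the first value that is a number and not a limit. Methyl in place of hydrogen on this oxygen on an aromatic ring gives an at least 1.1-fold lower number from compound 3 to compound 4 (0.04 log units; that floor lies within the scatter), while hydrogen in place of methyl on an oxygen on an aromatic ring gives an at least 1.1-fold lower number from compound 2 to compound 4 (0.04 log units; that floor lies within the scatter), and hydrogen in place of methoxy on an aromatic carbon gives an at least 1.1-fold lower number from compound 1 to compound 4 (0.04 log units; that floor lies within the scatter). Each of these steps is only a floor set by a limit, so the result gives this position a first measured value but does not show that hydroxy to methoxy here changes the read-out beyond the scatter, and most of the series remains at one limit: the limit of > 100000 nM in this assay, at which 3 of the 4 values shown sit.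

Going by these compounds, the true size of all three steps remains open, since each starts from a compound with only a limit. The compounds shown also leave open whether a longer chain on this oxygen, or an amine or a carboxylic acid on the same aromatic ring, would give a number clearly apart from that of compound 4.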